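A Ringless Amino Chain Replaces a Six-Membered Ring

A few compounds are considered here, and "the series" means these few. Any claim that something is new, unique, unknown or untested is made for them only; others in the source may bear on it.

In a functional assay on MCF7 cells (Homo sapiens) for cytotoxicity, read by fluorescence, with a stated time of 72 h (a higher number here means a weaker inhibitor, a lower number a stronger inhibitor), compound 1 `CC(C)c1n[nH]c2c(NCc3ccc(-c4ccccn4)cc3)nc(NCC(C)(C)O)nc12` gives 24 nM, while compound 2 `CC(C)c1n[nH]c2c(NCc3ccc(-c4ccccn4)cc3)nc(N3CCCCC3CCO)nc12` gives 133 nM, the higher of the two numbers and so the weaker result. Compound 3 `CC(C)c1n[nH]c2c(NCc3ccc(-c4ccccn4)cc3)nc(NCCN(C)C)nc12` has not yet been measured. It carries (2-(dimethylamino)ethyl)amino in place of 2-(2-hydroxyethyl)piperidin-1-yl on an aromatic carbon. For the measured compounds named here, one measured step bears on this change: a 5.5-fold higher number from compound 1 to compound 2 (0.74 log units; beyond the scatter), which lies beyond the scatter and came with the same ring-bearing group entering in place of (2-hydroxy-2-methylpropyl)amino. Compound 3 resembles compound 1 in having an amino chain without a ring, but the chain ends differently. Going by that step of a 5.5-fold higher number from compound 1 to compound 2 (0.74 log units; beyond the scatter), a somewhat smaller step toward a lower number is expected in this assay. The estimated change is a 2.7-fold lower number from compound 2 to compound 3 (0.42 log units; beyond the scatter). For compound 3, the estimated value is 50 nM, within an expected range of 15 nM to 170 nM.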

Compound 3, half-maximal inhibitory concentration: 225 nM
Compound 3: the middle estimate sits 4.5-fold (0.65 log units) below what was measured; measured number above the stated range.
By their numbers in this assay, from the lowest: compound 1; then compounds 2 and 3 (each within the scatter of the next).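

In this assay, an amino chain without a ring does not by itself bring back the number of compound 1. The ring-bearing 2-(2-hydroxyethyl)piperidin-1-yl gives way to (2-(dimethylamino)ethyl)amino with a 1.7-fold higher number from compound 2 to compound 3 (0.23 log units; within the scatter), so these two groups cannot be told apart here. The two ringless chains, however, do separate: (dimethylamino)methyl in place of 1-hydroxy-1-methylethyl at the chain end gives a 9.4-fold higher number from compound 1 to compound 3 (0.97 log units; beyond the scatter), which shows that among these compounds, what ends the chain counts at this position.

Nothing measured here gives a reason for this difference. Still open, as far as these compounds go, is how a chain ending in a carboxylic acid, or a longer chain carrying the same dimethylamino group, would compare with compound 1.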